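Swapping a basic ether side chain for a hydroxyethyl ether

The source may report more compounds than this note shows. Statements on the series, on what has been measured and on what is new or still open speak of the compounds shown alone.

Compound 1 `COc1ccc(C(c2ccc(OC(C)CN(C)C)cc2)c2cccc3ccccc23)c(OC)c1OC` is measured in a functional assay on MCF7 cells (Homo sapiens) for inhibition, read by sulforhodamine B assay, with a stated time of 48 h (on this read-out lower numbers stand for stronger inhibition and higher numbers for weaker inhibition), where compound 1 gives 13100 nM. Of the two compounds that yield a number, compound 1 carries the higher figure, yet its gap to compound 3 `COc1ccc(C(O)(Cc2ccccc2)c2cccc3ccccc23)c(OC)c1OC`, which gives 10600 nM, lies within the scatter, so no order between them can be drawn. Compound 2 `COc1ccc(C(O)(Cc2ccc(C)cc2)c2cccc3ccccc23)c(OC)c1OC` gives > 20000 nM in this assay, a limit rather than a number; it is the limit of > 20000 nM in this assay, at which 1 of the 3 values shown sits. Within the data shown here, the single step between measured compounds, an at least 1.8-fold lower number from compound 2 to compound 3 (0.27 log units; that floor lies within the scatter), concerns a methyl on an aromatic carbon and reaches only a floor within the scatter.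

Compound 4 `COc1ccc(C(c2ccc(OCCO)cc2)c2cccc3ccccc23)c(OC)c1OC` differs from compound 1 by 2-hydroxyethyl in place of 1-((dimethylamino)methyl)ethyl on an oxygen on an aromatic ring. Among the measured compounds shown here, no measured step touches the side chain on the aromatic oxygen, so the only comparison available says nothing about this change, and the three values given all fall in a narrow band. The step from compound 1 to compound 4 in this assay is therefore expected to stay within the scatter, with no clear direction: a 1.1-fold lower number from compound 1 to compound 4 (0.04 log units; within the scatter). Compound 4 is estimated at 12000 nM, with a range from 4000 nM to 30000 nM.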

Compound 4, half-maximal inhibitory concentration: > 20000 nM
Compound 4 was reported as a limit; the forecaster's own chance of this, stated with the estimate: 25%; middle value at least 1.6-fold (0.22 log units) away from the limit.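

Among these compounds, the side chain on the oxygen on an aromatic ring is the one place that the earlier comparison did not touch, and the result gives the first reading of it in this assay: an at least 1.5-fold higher number from compound 1 to compound 4 (0.18 log units; that floor lies within the scatter). Putting 2-hydroxyethyl in place of 1-((dimethylamino)methyl)ethyl therefore brings no lower number, although the step's floor does not establish a real difference between compound 1 and compound 4. Compound 4 gives a limit and not a number, so it joins compound 2 among the compounds without a numerical reading, and the series now divides evenly between numbers and limits: the limit of > 20000 nM in this assay, at which 2 of the 4 values shown sit.

The compounds shown leave open how far compound 4 truly stands from compound 1, and whether the nitrogen of the leaving chain or some other feature of that chain matters for the read-out. They also leave open how a 2-(dimethylamino)ethyl chain, a longer hydroxyalkyl chain or a carboxylic acid on the same oxygen would read in this assay.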